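This account rests on a few compounds, and the source may have more. Where it says the series, first, only, none or still open, it means among the compounds named here.

Working notes on the series.

Compound 3 `CC1=C(C(=O)Nc2ccc([N+](=O)[O-])cc2)C(c2cccc([N+](=O)[O-])c2)N=C(SCc2cccc(Cl)c2)N1` carries a 3-chlorobenzyl group on the sulfur, and in a functional assay on the whole organism (artery, strain albino) with Rattus norvegicus as the target, with a stated time of 300 min, at a dose of 10 mg/kg by the oral route (a higher number here means more inhibition at the dose given (going by the name of the read-out), a lower number less inhibition), compound 3 gives 21%. Among the measured compounds shown here, that places compound 3 second highest of the three numbers measured so far. Compound 2 `CC1=C(C(=O)Nc2ccc([N+](=O)[O-])cc2)C(c2cccc([N+](=O)[O-])c2)N=C(SCc2ccccc2Cl)N1` gives 15.9%, and compound 1 `CC1=C(C(=O)Nc2ccc([N+](=O)[O-])cc2)C(c2ccc(Br)cc2)N=C(SCc2ccc(F)cc2)N1` gives 34.4%; the gap from compound 3 to compound 2 lies within the scatter, the gap to compound 1 beyond it.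

The next compound, compound 4 `CC1=C(C(=O)Nc2ccc([N+](=O)[O-])cc2)C(c2cccc([N+](=O)[O-])c2)N=C(SCc2ccc(F)cc2)N1`, is not yet measured. It differs from compound 3 in one place: 4-fluorophenyl in place of 3-chlorophenyl on a saturated chain carbon bound to a sulfur.

For the measured compounds named here, only one measured step bears on a change of the benzyl group on the sulfur: a number 5.1 percentage points higher from compound 2 to compound 3 (within the scatter). That step moved a chlorine from one ring position to another and stayed within the scatter. Going by the values given here, the move to a 4-fluorobenzyl group is of a different kind, and the one measured 4-fluorobenzyl compound, compound 1, carries a different aryl at the saturated ring carbon, so its value cannot be read as a step from compound 3. The expected change is therefore small, with no clear direction, and is estimated as a number 4 percentage points higher from compound 3 to compound 4 (within the scatter).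

Compound 4 is expected to give 25% in this assay, with a range from 12% to 38%.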

Compound 4, a percentage reported as inhibition, in the whole organism at one dose (the size of the read-out at that dose, not a potency): 27.2%
The estimate for compound 4 lay 2.2 percentage points below the measured number; measured number inside the range.
By their numbers in this assay, from the lowest: compounds 2, 3, 4 and 1 (each within the scatter of the next, the first and the last beyond it).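

In this assay, among the compounds shown here, the change on the saturated chain carbon bound to a sulfur now has three members sharing the 3-nitrophenyl group, and 4-fluorophenyl in place of 2-chlorophenyl shows a number 11.3 percentage points higher from compound 2 to compound 4 (beyond the scatter) as the first step at this place that clears the scatter, whereas 4-fluorophenyl in place of 3-chlorophenyl shows a number 6.2 percentage points higher from compound 3 to compound 4 (within the scatter) and does not separate the two compounds. Compound 4 also opens a second place to comparison, the saturated ring carbon, where 3-nitrophenyl in place of 4-bromophenyl shows a number 7.2 percentage points lower from compound 1 to compound 4 (within the scatter) and so leaves these two aryl groups unresolved with the 4-fluorobenzyl group held constant. Nothing available explains why the 4-fluorophenyl and 2-chlorophenyl compounds differ.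

All the benzyl groups on the sulfur shown here carry a single halogen, so it remains open how an unsubstituted benzyl group, a methoxy-bearing benzyl group or a longer chain in its place would read in this assay. As far as these compounds go, it also remains open whether the step from 2-chlorophenyl to 4-fluorophenyl would hold with 4-bromophenyl on the saturated ring carbon.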